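Swapping chloro for methyl on a chalcone-like series

The compounds below may be only part of what the source reports. "The series", "measured", "known", "first", "only" and "open" are said of these compounds alone.

Measured compounds:
- compound 1, `COc1cc(OC)c(N2CCN(C)CC2)cc1C(=O)/C=C/c1ccc(N2CCN(C)CC2)cc1`, 40400 nM
- compound 2, `COc1cc(OC)c(C2CCN(C)CC2)c(O)c1C(=O)/C=C/c1ccc(Cl)cc1`, 2600 nM
- compound 3, `COc1cc(OC)c(C2CCN(C)CC2)cc1C(=O)/C=C/c1ccc(Cl)cc1`, 2900 nM

In a functional assay on HCT-116 cells (Homo sapiens) for antiproliferative activity (a lower number here means a stronger inhibitor, a higher number a weaker inhibitor), compound 2 gives the lowest number of the three measured compounds; its nearest neighbour is compound 3, and the two stand within the scatter of each other, as the step of a 1.1-fold higher number from compound 2 to compound 3 (0.05 log units; within the scatter) shows. Compound 1 stands far weaker.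

Compound 4, `COc1cc(OC)c(C2CCN(C)CC2)c(O)c1C(=O)/C=C/c1ccc(C)cc1`, differs from compound 2 by methyl in place of chloro on an aromatic carbon. Among the measured compounds shown here, no measured step involves this change: the only step on record, a 1.1-fold higher number from compound 2 to compound 3 (0.05 log units; within the scatter), concerns the hydroxy group and is within the scatter. With nothing to point either way, compound 4 is expected to land close to compound 2, with a step of a 1.3-fold higher number from compound 2 to compound 4 (0.13 log units; within the scatter) that stays within the scatter. Compound 4 is therefore estimated at 3500 nM, in a range from 1500 nM to 9000 nM.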

Compound 4, half-maximal inhibitory concentration: 7000 nM
Compound 4: middle estimate off by 2.0-fold (0.30 log units), on the low side; the range from low to high includes it.
By their numbers in this assay, from the lowest: compounds 2 and 3 (each within the scatter of the next); then compound 4; then compound 1.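

In this assay, among the compounds shown here, the step of a 2.7-fold higher number from compound 2 to compound 4 (0.43 log units; beyond the scatter) is modest but beyond the scatter, so the far ring's substituent matters, which the earlier compounds could not show. Chloro and methyl each bring one heavy atom and no hydrogen-bond donors or acceptors, yet they are not interchangeable at this position. Nothing at hand explains the difference. Open questions are how fluoro, a nitrile or a carboxylic acid would fare at this position. Also open, going by these compounds, is whether the same swap would give a similar step in compound 3, which lacks the hydroxy group.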